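Indole hydrazones: removing the methoxy from compound 2

A few compounds are considered here, and "the series" means these few. Any claim that something is new, unique, unknown or untested is made for them only; others in the source may bear on it.

Measured compounds:
- compound 1, `O=C(N/N=C\c1cn(Cc2ccc(Cl)cc2)c2cc(F)ccc12)c1c[nH]c2ccccc12`: 5300 nM
- compound 2, `COc1ccc2c(c1)c(/C=N\NC(=O)c1c[nH]c3ccccc13)cn2Cc1ccc(Cl)cc1`: 82700 nM

Two hydrazones have been run in a functional assay on MDA-MB-231 cells (Homo sapiens) for cytotoxicity; a higher number here means a weaker inhibitor, a lower number a stronger inhibitor. Compound 1 gives 5300 nM, while compound 2 gives 82700 nM. Compound 2 therefore stands at the highest number of the two, and the gap to compound 1 is well beyond the scatter, so compound 2 is the weaker of the pair on the data available.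

Compound 3, `O=C(N/N=C\c1cn(Cc2ccc(Cl)cc2)c2ccccc12)c1c[nH]c2ccccc12`, is the next compound for this assay. It differs from compound 2 in one place: hydrogen in place of methoxy on an aromatic carbon. Compound 1 and compound 3 are not related by a single change, so their two values only show where the series has landed so far.

The change from compound 2 to compound 3 is expected to lower the number, since the only other substitution pattern seen, in compound 1, sits far below compound 2; the expected step is a 9.2-fold lower number from compound 2 to compound 3 (0.96 log units; beyond the scatter). Compound 3 is therefore estimated at 9000 nM, within a range of 2500 nM to 40000 nM, with the direction more secure than the size.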

Compound 3, half-maximal inhibitory concentration: 66400 nM
Compound 3: the middle estimate sits 7.4-fold (0.87 log units) below what was measured; measured number above the stated range.
By their numbers in this assay, from the lowest: compound 1; then compounds 3 and 2 (each within the scatter of the next).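

In this assay, hydrogen in place of methoxy gives a 1.2-fold lower number from compound 2 to compound 3 (0.10 log units; within the scatter), so at this aromatic carbon, meta to a fused ring and para to a fused ring, the two groups cannot be told apart, and the methoxy is not what keeps compound 2 far from compound 1. The larger step belongs to the other single change: hydrogen in place of fluoro gives a 13-fold higher number from compound 1 to compound 3 (1.10 log units; beyond the scatter), which ties the lower number of compound 1 to its fluoro, standing on a different aromatic carbon of the shared core. Nothing at hand explains either step.

Going by these compounds alone, what stays open is whether the methoxy carbon is indifferent to substitution in general, since methoxy and hydrogen are the only two groups seen there, and an amine or a carboxylic acid on that carbon could read differently. Going by these compounds, it is equally open whether the gain in compound 1 is specific to fluoro or to its carbon, which a chloro or a nitrile on that same carbon, and a fluoro on the methoxy carbon, would help separate.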